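Hydroxymethyl in Place of Ethoxycarbonyl: Estimating Compound 4

The compounds below may be only part of what the source reports. "The series", "measured", "known", "first", "only" and "open" are said of these compounds alone.

Compound 2 `CCOC(=O)CCCCCOc1ccc2c(=O)c(-c3ccc(O)cc3)coc2c1` gives 280 nM in an assay (Cricetulus griseus) for inhibition of aldehyde dehydrogenase, mitochondrial (Homo sapiens) (on this read-out lower numbers stand for stronger inhibition and higher numbers for weaker inhibition), and stands with the lowest of the two numbers shown. Its nearest neighbour, compound 3 `O=c1c(-c2ccc(O)cc2)coc2cc(OCCCCCCCCCO)ccc12`, gives 700 nM in this assay. Compound 1 `O=C(O)COc1ccc(-c2coc3cc(OCC(=O)O)ccc3c2=O)cc1` reaches only a limit in this assay, >> 9000 nM, which is not a number (the limit of >> 9000 nM in this assay, at which 1 of the 3 values shown sits). Compound 4 `O=c1c(-c2ccc(O)cc2)coc2cc(OCCCCCCO)ccc12` has not yet been measured in this assay; it differs from compound 2 by hydroxymethyl in place of ethoxycarbonyl on a saturated chain carbon, five bonds along the chain from an oxygen on an aromatic ring. Among the compounds with values here, the one measured step that bears on this change is a 2.5-fold higher number from compound 2 to compound 3 (0.40 log units; beyond the scatter), where ethoxycarbonyl gave way to 4-hydroxybutyl at the same place on the chain. Compound 4 carries a hydroxymethyl instead, so the chain beyond that carbon is shorter, yet the ethoxycarbonyl is again exchanged for a group bearing a hydrogen-bond donor; a modest rise of similar size is therefore expected, and compound 4 is estimated at 600 nM, within 250 nM to 1400 nM. The step this estimate means, a 2.1-fold higher number from compound 2 to compound 4 (0.33 log units; beyond the scatter), is expected to sit just beyond the scatter.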

Compound 4, half-maximal inhibitory concentration: 120 nM
Compound 4: the middle estimate sits 5.0-fold (0.70 log units) above what was measured; measured number outside the range, below it.
By their numbers in this assay, from the lowest: compound 4; then compound 2; then compound 3. At a limit, above all of these: compound 1.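

In this assay, replacing ethoxycarbonyl at this chain carbon does not move the number in one fixed direction: hydroxymethyl gives a 2.3-fold lower number from compound 2 to compound 4 (0.37 log units; beyond the scatter), whereas 4-hydroxybutyl gave a 2.5-fold higher number from compound 2 to compound 3 (0.40 log units; beyond the scatter). Compounds 3 and 4 both end in hydroxy and differ in chain length, and that difference alone gives a 5.8-fold lower number from compound 3 to compound 4 (0.77 log units; beyond the scatter), so the end group by itself does not set the outcome and the length of the chain carrying it matters at this position. Nothing measured here gives a cause for these steps.

From the compounds shown here alone, whether a shorter chain ending in hydroxy would lower the number further, or compound 4 already lies near the best length, remains open. How an amine at the chain end would compare with the hydroxy of compound 4 is also unresolved.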